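A few compounds are considered here, and "the series" means these few. Any claim that something is new, unique, unknown or untested is made for them only; others in the source may bear on it.

Among the compounds with values here, in an ADME assay on THP-1 cells (Homo sapiens) for cytotoxicity, read by MTT assay, with a stated time of 72 h (on this read-out lower numbers stand for higher toxicity in this test and higher numbers for lower toxicity in this test), compound 1 (`Cc1cc(C)c(-c2cn(Cc3cc(-c4ccccc4)no3)nn2)cc1C`) gives 201000 nM and is the only member of the series with a number. Compound 2 (`COc1ccc(-c2cn(Cc3cc(-c4ccccc4)no3)nn2)c(C)c1`) stands at "not determined" (no result reported) and compound 3 (`COc1ccc(-c2cc(Cn3cc(-c4cc(C)c(C)cc4C)nn3)on2)cc1`) at "not determined" (no result reported) so compound 3 has no place on the scale. Compound 4 (`COc1ccc(-c2cc(Cn3cc(-c4cc(C)c(C)cc4C)nn3)on2)cc1OC`) differs from it by one change (methoxy in place of hydrogen on an aromatic carbon) that takes 4-methoxyphenyl to 3,4-dimethoxyphenyl, with methoxy in place of hydrogen on an aromatic carbon, ortho to a methoxy group. Within the data shown here, no measured step is available, so no shift beyond the usual scatter is expected in this assay from this change, and the only anchor is compound 1 at 201000 nM in the series. Compound 4 is expected near 170000 nM with an estimated range of 60000 nM to 400000 nM for the result.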

Compound 4, half-maximal cytotoxic concentration: > 500000 nM
Compound 4 was reported as a limit (the forecaster's own chance of this, stated with the estimate: 25%); at least 2.9-fold (0.46 log units) between middle value and limit.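

In this assay compound 4 stands at > 500000 nM, which is a limit and not a number: the limit of > 500000 nM in this assay, at which 1 of the 4 values shown sits. The series now has its first readable step: 3,4-dimethoxyphenyl in place of phenyl on an aromatic carbon gives an at least 2.4-fold higher number from compound 1 to compound 4 (0.39 log units; beyond the scatter), towards lower toxicity in this test. The step from compound 3 to compound 4 cannot be read, as compound 3 has no number.

Open, as far as these compounds go, is how much of this shift belongs to the added methoxy alone, and whether an amine or a carboxylic acid on this aromatic ring would give a value inside the range of the assay.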